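Notes on the 4-chlorophenyl step from compound 2

This account rests on a few compounds, and the source may have more. Where it says the series, first, only, none or still open, it means among the compounds named here.

In a functional assay on K562 cells (Homo sapiens) for inhibition, read by trypan blue exclusion, with a stated time of 72 h (a lower number here means a stronger inhibitor, a higher number a weaker inhibitor), compound 1 (`COc1ccc(Nc2ncc3cc(S(=O)(=O)c4ccc(Cl)cc4)c(=O)n(C)c3n2)cc1`) gives 15000 nM as its half-maximal inhibitory concentration. Compound 2 (`Cc1ccc(S(=O)(=O)c2cc3cnc(Nc4cnc5[nH]ccc5c4)nc3n(C)c2=O)cc1`) gives 15000 nM in the same read-out and stands level with compound 1, within the scatter. Compound 3 (`Cn1c(=O)c(S(=O)(=O)c2ccc(Cl)cc2)cc2cnc(Nc3cnc4[nH]ccc4c3)nc21`) has not yet been measured. It differs from compound 2 as follows: chloro in place of methyl on an aromatic carbon, with chloro in place of methyl on an aromatic carbon, para to a large group, so that 4-methylphenyl becomes 4-chlorophenyl. For the measured compounds named here, no measured pair isolates this change. Compound 1 already carries the 4-chlorophenyl group at 15000 nM in this assay, so no step beyond the scatter is expected, in either direction. The estimated change is a 1.3-fold lower number from compound 2 to compound 3 (0.10 log units; within the scatter) in this assay, which stays within the scatter. For compound 3 the estimated value is 12000 nM ( expected range 4000 nM to 30000 nM).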

Compound 3, half-maximal inhibitory concentration: 5000 nM
For compound 3 the middle estimate is 2.4-fold (0.38 log units) above the measured one; low and high end bracket the measured number.
By their numbers in this assay, from the lowest: compound 3; then compounds 1 and 2 (each within the scatter of the next).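

In this assay, chloro in place of methyl on an aromatic carbon, para to a large group, gives a 3.0-fold lower number from compound 2 to compound 3 (0.48 log units; beyond the scatter), so this position responds to a change of a single heavy atom. With the 4-chlorophenyl group held fixed, a group of 9 heavy atoms in place of a group of 8 heavy atoms, on a nitrogen on an aromatic ring, gives a 3.0-fold lower number from compound 1 to compound 3 (0.48 log units; beyond the scatter), which shows that this second place also moves the number. No data at hand bear on the reason for either step.

As far as these compounds go, whether the chloro-for-methyl step carries over to compounds with the group of 8 heavy atoms on that nitrogen stays open. Also open, from the compounds shown here alone, is how fluoro, methoxy, nitrile or an amine would read at the same ring position.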